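A few compounds are considered here, and "the series" means these few. Any claim that something is new, unique, unknown or untested is made for them only; others in the source may bear on it.

Measured in a functional assay on HL-60 cells (Homo sapiens) for antiproliferative activity, read by MTT assay; a higher number here means a weaker inhibitor, a lower number a stronger inhibitor:
- compound 1 `CCCCC[C@@H]1O[C@H](COCc2ccccc2)[C@@H](OCc2ccccc2)[C@H](OCc2ccccc2)[C@H]1O`: "not active" (no number reported)
- compound 2 `CCC[C@@H]1O[C@H](COCc2ccccc2)[C@@H](OCc2ccccc2)[C@H](OCc2ccccc2)[C@H]1O`: 11700 nM

Among the compounds with values here, compound 2, at 11700 nM, holds the only number, and compound 1 gives no number. Compound 3 `OCCC[C@@H]1O[C@H](COCc2ccccc2)[C@@H](OCc2ccccc2)[C@H](OCc2ccccc2)[C@H]1O` turns propyl into 3-hydroxypropyl: hydroxy in place of hydrogen on a saturated chain carbon, three bonds along the chain from a saturated ring carbon. Within the data shown here, no measured pair isolates this change, so the expectation rests on compound 2 at 11700 nM alone. In this assay, a slight weakening, perhaps none beyond the scatter, is expected. The expected 1.2-fold higher number from compound 2 to compound 3 (0.08 log units; within the scatter) is therefore small. The estimate for compound 3 is 14000 nM, with an expected range of 5000 nM to 40000 nM.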

Compound 3, half-maximal inhibitory concentration: 19300 nM
Beside the measured number, compound 3's estimate is 1.4-fold (0.14 log units) below it; low and high end bracket the measured number.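

In this assay hydroxy in place of hydrogen on a saturated chain carbon, three bonds along the chain from a saturated ring carbon, gives a 1.6-fold higher number from compound 2 to compound 3 (0.22 log units; within the scatter) and so cannot be told apart from the propyl parent. This place on the chain therefore accepts the hydroxy group without a measurable loss, and compound 3 gives the series a second number. No available evidence bears on the reason for this result.
As far as these compounds go, whether an amine or a carboxylic acid at this same place would read alike stays open. So does the reading of a longer chain carrying the hydroxy group.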